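The source may report more compounds than this note shows. Statements on the series, on what has been measured and on what is new or still open speak of the compounds shown alone.

Measured compounds in a functional assay on SK-OV-3 cells (Homo sapiens) for antiproliferative activity, read by MTT assay; a lower number here means a stronger inhibitor, a higher number a weaker inhibitor:

Compound 1, `Cc1ccc(C(=O)C(=C2NCCN2)c2c(Cl)c(Cl)c(C#N)c(Cl)c2C#N)cc1`: 9.2 ug/mL
Compound 2, `Cc1ccc(C(=O)C(=C2NCCN2)c2c(Cl)c(F)c(C#N)c(F)c2C#N)cc1`: 6.7 ug/mL
Compound 3, `COc1ccc(C(=O)C(=C2NCCN2)c2c(Cl)c(Cl)c(C#N)c(Cl)c2C#N)cc1`: 6.4 ug/mL

Three compounds share the same arrangement of a carbonyl, an exocyclic double bond to a cyclic amidine, and a polysubstituted dicyano aryl ring; they differ in the aryl ketone substituent and in the halogen pattern of the dicyano ring. The difference between the core of compound 1 and the core of compound 2 is not broken down here. Among the measured compounds shown here, the one change that can be followed is methoxy in place of methyl on an aromatic carbon, which in this assay gave a 1.4-fold lower number from compound 1 to compound 3 (0.16 log units; within the scatter). Compound 2 sits between the others: its value is within the scatter of compound 3 and within the scatter of compound 1, so no order among the three can be stated.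

Compound 4, `COc1ccc(C(=O)C(=C2NCCN2)c2c(Cl)c(F)c(C#N)c(F)c2C#N)cc1`, is not yet measured. It carries the same change relative to compound 2, (methoxy in place of methyl on an aromatic carbon), and the surroundings of the change are the same as in the step from compound 1 to compound 3, so it is the same change. For the measured compounds named here, on the dicyano ring of compound 2 this change has no precedent, and a deviation from the earlier step cannot be excluded. The expected step is a 1.3-fold lower number from compound 2 to compound 4 (0.13 log units; within the scatter), resting on the small step seen from compound 1 to compound 3, a 1.4-fold lower number from compound 1 to compound 3 (0.16 log units; within the scatter). For compound 4 the estimate in this assay is 5 ug/mL, expected to lie between 2.5 ug/mL and 10 ug/mL.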

Compound 4, half-maximal inhibitory concentration: 1.1 ug/mL
Beside the measured number, compound 4's estimate is 4.5-fold (0.66 log units) above it; measured number outside the range, below it.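

In this assay, going from 4-methylphenyl to 4-methoxyphenyl on the core of compound 2 gives a 6.1-fold lower number from compound 2 to compound 4 (0.78 log units; beyond the scatter), so methoxy in place of methyl has a step beyond the scatter on this core. Set beside the earlier step, the same change does not carry over at the same size from one core to the other: the same change on two cores in this assay, a 1.4-fold lower number (0.16 log units; within the scatter) from compound 1 to compound 3 and a 6.1-fold lower number (0.78 log units; beyond the scatter) from compound 2 to compound 4, 4.2-fold (0.63 log units) apart, beyond the scatter of two such steps. The size of this step read on one core is therefore a poor guide to its size on the other, but the result does not show why the two cores differ, and one pair on each core gives no rule for any further core in the series.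

The compounds shown leave open whether a step of this size also appears on the core of compound 2 with other groups at the same place on the aryl ketone ring, such as ethoxy, hydroxy or a dimethylamino group. Among the compounds shown here, they also leave open which of the chlorine and fluorine atoms on the dicyano ring goes with the gap between the two steps, as the two cores differ at more than one atom and no compound separates these replacements.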